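The source may hold more compounds than are shown below. What is called first, only, known or untested is meant among the compounds shown, and "the series" means these compounds.

Measured compounds:
Compound 1, `C[C@]1(COc2ccc(S(=O)(=O)N3CCOCC3)cc2)Cn2cc([N+](=O)[O-])nc2O1`: 20 ug/mL
Compound 2, `CCc1ccc(NC(=O)Nc2ccc(OC[C@@]3(C)Cn4cc([N+](=O)[O-])nc4O3)cc2)cc1`: < 1 ug/mL

In a physicochemical assay for solubility, read by HPLC, with a stated time of 4 h, at pH 7 (on this read-out lower numbers stand for lower solubility and higher numbers for higher solubility), compound 1 gives 20 ug/mL. For compound 2 the read-out is < 1 ug/mL, which is a limit of the assay and not a number, as noted in the limit of < 1 ug/mL in this assay, at which 1 of the 2 values shown sits. Compound 2 thus stands at a limit, and its solubility is not pinned to a number; only compound 1 carries an actual value here. Compound 3, `C[C@]1(COc2ccc(NC(=O)Nc3ccc(Cl)cc3)cc2)Cn2cc([N+](=O)[O-])nc2O1`, has not yet been measured. It differs from compound 2 by chloro in place of ethyl on an aromatic carbon, para to a large group, so that a 4-ethylphenyl becomes a 4-chlorophenyl. Going by the values given here, no step between two measured compounds is available for this change, so there is no measured yardstick for it. The step of a number no lower from compound 2 to compound 3 (the limit leaves the size open) is expected to be small, within the usual scatter, with no direction claimed. Compound 3 is therefore expected to give about 1 ug/mL, somewhere between 0.3 ug/mL and 3 ug/mL, and may well again return only a limit.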

Compound 3, solubility: 6.66 ug/mL
Compound 3: the middle estimate sits 6.7-fold (0.82 log units) below what was measured; the measured number lies above the stated range.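

In this assay, the change of ethyl to chloro on this aromatic carbon, para to a large group, now has a measured size: an at least 6.6-fold higher number from compound 2 to compound 3 (0.82 log units; beyond the scatter). The outer end of the molecule is therefore not a silent spot, as replacing one small group with another, with one heavy atom in place of two and no hydrogen-bond donor or acceptor on either side, is enough to move this read-out clearly. Compound 2 stands at a limit, < 1 ug/mL, which is not a number, so the step has a lower bound but no known full size: the limit of < 1 ug/mL in this assay, at which 1 of the 3 values shown sits.

The compounds shown carry only ethyl and chloro at this position, so it remains open how a fluoro, a methoxy or an amine would read there, and whether the order would follow any simple trend. On these data alone, this is also a single pair, so it remains open whether the same swap would move the read-out in the same direction, or by a similar amount, on a different core.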